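Acetyl to Benzyloxycarbonyl on the Exocyclic Chain: Compound 4

The compounds below may be only part of what the source reports. "The series", "measured", "known", "first", "only" and "open" are said of these compounds alone.

Measured so far in a functional assay on HT-1080 cells (Homo sapiens) for cytotoxicity, read by MTT assay, with a stated time of 48 h; on this read-out higher numbers stand for weaker inhibition and lower numbers for stronger inhibition:
Compound 1 `CC(=O)/C=C1\C[C@H]2SC(C)(C)[C@H](C(=O)OC(c3ccccc3)c3ccccc3)N2C1=O` reaches only the assay limit, > 100000 nM.
Compound 2 `CC1(C)S[C@@H]2/C(=C\C(=O)OC(c3ccccc3)c3ccccc3)C(=O)N2[C@H]1C(=O)OC(c1ccccc1)c1ccccc1` gives 15200 nM.
Compound 3 `CC(=O)/C=C1/C(=O)N2[C@@H]1SC(C)(C)[C@@H]2C(=O)OC(c1ccccc1)c1ccccc1` gives 20800 nM.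

Compound 3 holds the higher of the two numbers, but its gap to compound 2 lies within the scatter, so the two cannot be ordered. Compound 1 is known only as a limit, with one of three values sitting there (the limit of > 100000 nM in this assay, at which 1 of the 3 values shown sits).

Compound 4 `CC1(C)S[C@@H]2/C(=C\C(=O)OCc3ccccc3)C(=O)N2[C@H]1C(=O)OC(c1ccccc1)c1ccccc1` is compound 3 with benzyloxy in place of methyl on a carbonyl carbon. Compound 2 already carries an ester on the same double-bonded chain and gives a number close to compound 3, so no step beyond the scatter is expected from compound 3 to compound 4: a 1.2-fold lower number from compound 3 to compound 4 (0.06 log units; within the scatter). Compound 4 is therefore estimated at 18000 nM, between 6000 nM and 50000 nM.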

Compound 4, half-maximal inhibitory concentration: 11700 nM
For compound 4 the middle estimate is 1.5-fold (0.19 log units) above the measured one; the range from low to high includes it.
By their numbers in this assay, from the lowest: compounds 4, 2 and 3 (each within the scatter of the next). At a limit, above all of these: compound 1.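

Putting benzyloxy in place of methyl on a carbonyl carbon adds an aromatic ring, yet in this assay the step stays within the scatter: a 1.8-fold lower number from compound 3 to compound 4 (0.25 log units; within the scatter). Between the two esters, hydrogen in place of phenyl on a saturated chain carbon bound to an aromatic carbon and an oxygen also leaves the result within the scatter, with a 1.3-fold lower number from compound 2 to compound 4 (0.11 log units; within the scatter). Nothing measured here explains why these numbers stay so close.

From the compounds shown here alone, whether an amine or a carboxylic acid at this carbonyl carbon would move the number beyond the scatter remains open.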